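Chloro in place of propoxy: a solubility estimate

The compounds below may be only part of what the source reports. "The series", "measured", "known", "first", "only" and "open" are said of these compounds alone.

Compound 1 `CCOC(=O)c1c(-c2cccc(-c3ccccc3)c2)[nH]c2cc(OC)ccc2c1=O`: 200 nM
Compound 2 `CCOC(=O)c1c(-c2cccc(OCC)c2)[nH]c2cc(OC)ccc2c1=O`: 8700 nM
Compound 3 `CCCOc1cccc(-c2[nH]c3cc(OC)ccc3c(=O)c2C(=O)OCC)c1`: 5800 nM

These values come from a physicochemical assay for solubility, at pH 7.4; on this read-out higher numbers stand for higher solubility and lower numbers for lower solubility. Compound 3 stands level with compound 2, as a 1.5-fold lower number from compound 2 to compound 3 (0.18 log units; within the scatter) shows, and far from the remaining compound, as a 29-fold higher number from compound 1 to compound 3 (1.46 log units; beyond the scatter) shows. Compound 4 `CCOC(=O)c1c(-c2cccc(Cl)c2)[nH]c2cc(OC)ccc2c1=O` has chloro in place of propoxy on an aromatic carbon. Within the data shown here, no measured compound carries chloro, so the evidence is indirect. Two large steps, a 44-fold higher number from compound 1 to compound 2 (1.64 log units; beyond the scatter) and a 29-fold higher number from compound 1 to compound 3 (1.46 log units; beyond the scatter), came from replacing phenyl, a ring, with a group without one. Chloro and propoxy both have no ring, and the change from ethoxy to propoxy, a 1.5-fold lower number from compound 2 to compound 3 (0.18 log units; within the scatter), stayed small. In this assay, no change beyond the scatter is therefore expected, with the estimated step being a 1.5-fold lower number from compound 3 to compound 4 (0.16 log units; within the scatter). The estimated value for compound 4 is 4000 nM, with an expected range from 1200 nM to 12000 nM.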

Compound 4, solubility: 58000 nM
For compound 4 the middle estimate is 15-fold (1.16 log units) below the measured one; the measured number lies above the stated range.
By their numbers in this assay, from the lowest: compound 1; then compounds 3 and 2 (each within the scatter of the next); then compound 4.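

In this assay, the group at this place matters even when no ring is involved: chloro in place of propoxy gives (a 10-fold higher number from compound 3 to compound 4 (1.00 log units; beyond the scatter)), and chloro in place of ethoxy gives (a 6.7-fold higher number from compound 2 to compound 4 (0.82 log units; beyond the scatter)). The near-level pair of ethoxy and propoxy therefore did not predict chloro. Chloro in place of phenyl gives (a 290-fold higher number from compound 1 to compound 4 (2.46 log units; beyond the scatter)). The data shown offer no measured explanation for these steps. On these data alone, whether fluoro, bromo or an amine at this place would stand near chloro remains open.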